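The source may report more compounds than this note shows. Statements on the series, on what has been measured and on what is new or still open speak of the compounds shown alone.

Measured compounds:
- compound 1, `COc1ccc(/C=C/C=C/C(=O)c2cc(Cl)ccc2O)cc1`, 153 nM in an in vitro assay on cells for inhibition of Amine oxidase [flavin-containing] B (Homo sapiens), read by Amplex Red, with a stated time of 15 min; a higher number here means a weaker inhibitor, a lower number a stronger inhibitor
- compound 2, `O=C(/C=C(O)/C=C/c1ccccc1)c1ccccc1O`, 1160 nM in this assay
- compound 3, `COc1ccc(/C=C/C=C/C(=O)c2cc(F)ccc2O)cc1`, 726 nM in this assay

Compound 2 gives the highest of the three numbers in this assay. Against compound 3 the gap is within the scatter; against compound 1 it is beyond it. For the measured compounds named here, the only single-place step in the set is a 4.7-fold higher number from compound 1 to compound 3 (0.68 log units; beyond the scatter), a change in the halogen on the core of compound 1, which has no counterpart in the step considered here.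

Compound 4, `O=C(/C=C(O)/C=C/c1ccc(O)cc1)c1ccccc1O`, differs from compound 2 by hydroxy in place of hydrogen on an aromatic carbon. Going by the values given here, no measured pair in the set shows hydroxy in place of hydrogen, nor any other change on that phenyl ring alone, so nothing in the numbers sets the direction. Compounds 1 and 3 differ from compound 2 in more than one place and their values can only be read as values.

Among the compounds with values here, with no bearing step, no change beyond the scatter is expected; the estimated step is a 1.3-fold lower number from compound 2 to compound 4 (0.11 log units; within the scatter). Compound 4 is therefore expected at 900 nM, with a range of 350 nM to 2500 nM.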

Compound 4, half-maximal inhibitory concentration: 26.5 nM
For compound 4 the middle estimate is 34-fold (1.53 log units) above the measured one, and the stated range ends above it.
By their numbers in this assay, from the lowest: compound 4; then compound 1; then compounds 3 and 2 (each within the scatter of the next).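

In this assay, the change from phenyl to 4-hydroxyphenyl gives a 44-fold lower number from compound 2 to compound 4 (1.64 log units; beyond the scatter), a large step from a single added hydroxy para to a large group. For the compounds shown here, the only earlier single-place step, a 4.7-fold higher number from compound 1 to compound 3 (0.68 log units; beyond the scatter), concerned the halogen on the core of compound 1, so this is the first sign that the ring carrying the new hydroxy also bears strongly on the number. No measurement at hand accounts for the size of this step.

From the compounds shown here alone, whether an amine or a carboxylic acid at this place would give a similar step remains open, as does the effect of hydroxy on another carbon of that ring. Also open, going by these compounds, is whether the same change would have a similar effect on the halogen-bearing core of compound 1.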